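The compounds below may be only part of what the source reports. "The series", "measured", "known", "first", "only" and "open" are said of these compounds alone.

Three compounds that share one core, differing only in the group attached to the carbonyl carbon of the amide, have been tested in a functional assay on HepG2 cells (Homo sapiens) for cytotoxicity, read by MTT assay, with a stated time of 72 h; a lower number here means a stronger inhibitor, a higher number a weaker inhibitor. Compound 1 `CN1[C@@H]2c3[nH]c4ccccc4c3C[C@H]1[C@H](C#N)N1[C@@H](CNC(=O)c3ccc(F)cc3)c3[nH]c4ccccc4c3C[C@@H]21` gives 210 nM. Compound 2 `CCc1ccc(C(=O)NC[C@H]2c3[nH]c4ccccc4c3C[C@H]3[C@H]4c5[nH]c6ccccc6c5C[C@@H]([C@H](C#N)N23)N4C)cc1` gives 570 nM. Compound 3 `CN1[C@@H]2c3[nH]c4ccccc4c3C[C@H]1[C@H](C#N)N1[C@@H](CNC(=O)c3ccc4ccccc4c3)c3[nH]c4ccccc4c3C[C@@H]21` gives 1210 nM, the highest number of the three: the step of a 5.8-fold higher number from compound 1 to compound 3 (0.76 log units; beyond the scatter) and the step of a 2.1-fold higher number from compound 2 to compound 3 (0.33 log units; beyond the scatter) both run upward, each beyond the scatter, so compound 3 is the weakest of the three measured compounds in this assay.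

Compound 4 `CN1[C@@H]2c3[nH]c4ccccc4c3C[C@H]1[C@H](C#N)N1[C@@H](CNC(=O)/C=C/c3cccc(C(F)(F)F)c3)c3[nH]c4ccccc4c3C[C@@H]21` is not yet measured. It differs from compound 3 in one place: 2-(3-(trifluoromethyl)phenyl)ethenyl in place of naphthalen-2-yl on a carbonyl carbon. Within the data shown here, no measured pair carries exactly this change. The two steps that bear on it, a 5.8-fold higher number from compound 1 to compound 3 (0.76 log units; beyond the scatter) and a 2.1-fold higher number from compound 2 to compound 3 (0.33 log units; beyond the scatter), show that putting naphthalen-2-yl on the carbonyl carbon in place of a singly substituted phenyl raised the number; compound 4 removes the naphthalen-2-yl again and brings in a singly substituted phenyl, though one held on an ethenyl linker. Among the measured compounds shown here, a modest downward step is therefore expected, a 2.0-fold lower number from compound 3 to compound 4 (0.30 log units; within the scatter), with wide uncertainty because the linker has no precedent here. Compound 4 is estimated at 600 nM, in a range from 200 nM to 2000 nM.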

Compound 4, half-maximal inhibitory concentration: 540 nM
For compound 4 the middle estimate is 1.1-fold (0.05 log units) above the measured one, and the stated range covers the measured number.
By their numbers in this assay, from the lowest: compound 1; then compounds 4 and 2 (each within the scatter of the next); then compound 3.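

In this assay, the position on the carbonyl carbon tolerates an ethenyl linker: 2-(3-(trifluoromethyl)phenyl)ethenyl in place of naphthalen-2-yl gives a 2.2-fold lower number from compound 3 to compound 4 (0.35 log units; beyond the scatter), and in place of 4-ethylphenyl it gives a 1.1-fold lower number from compound 2 to compound 4 (0.02 log units; within the scatter), so those two groups cannot be told apart here. In place of 4-fluorophenyl, the same group gives a 2.6-fold higher number from compound 1 to compound 4 (0.41 log units; beyond the scatter), which leaves compound 1 with the lowest number of the four. Nothing available here explains why these steps occur.

The part played by the ethenyl linker cannot be separated from that of the trifluoromethyl group: no compound shown carries one without the other. Also open, going by these compounds, is how an amine or a carboxylic acid on the phenyl ring, or a longer saturated carbon chain in place of the ethenyl linker, would read in this assay.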